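The source may hold more compounds than are shown below. What is called first, only, known or untested is meant among the compounds shown, and "the series" means these compounds.

Compound 1 `Clc1cncc(N2CCCNCCC2)c1` stands highest of the two numbers measured here. In an assay on HEK293 cells with Neuronal acetylcholine receptor; alpha4/beta2 (Homo sapiens) as the target, read by FLIPR and calcium flux (a lower number here means a smaller maximal response, a higher number a larger maximal response), compound 1 gives 103%. Compound 2 `COc1cc(N2CCNCC2)cnc1Br` gives 68% in this assay, a gap beyond the scatter, but this pair differs in several places at once. Compound 3 `COc1cncc(N2CCCNCCC2)c1` differs from compound 1 by methoxy in place of chloro on an aromatic carbon. Among the compounds with values here, no measured pair isolates this change, so its effect is not yet known. The step of a number 13 percentage points lower from compound 1 to compound 3 (beyond the scatter) is expected to be a modest decrease, and it may well fall within the scatter. Compound 3 is therefore estimated to reach 90%, within a range from 65% to 110%.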

Compound 3, largest response reached (reported as efficacy), in percent of the reference or control that the assay uses: 89%
Compound 3: the middle estimate sits 1 percentage points above what was measured; the range from low to high includes it.
By their numbers in this assay, from the lowest: compound 2; then compound 3; then compound 1.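

Within the data shown here, putting methoxy in place of chloro, two atoms from the ring nitrogen, gives the first direct reading of this position: in this assay the change gives a number 14 percentage points lower from compound 1 to compound 3 (beyond the scatter). The response is lowered only modestly, so this position can carry a group of two heavy atoms, including a hydrogen-bond acceptor, without losing most of the response. Nothing available explains the drop.

From the compounds shown here alone, how an amine or a longer chain such as ethoxy would behave at this position remains open. So does whether the same change would give a similar step on the core of compound 2.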